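Removing a para-chloro substituent on two indole-based cores

The compounds below may be only part of what the source reports. "The series", "measured", "known", "first", "only" and "open" are said of these compounds alone.

Compound 1 `CC(=O)/C(=C\c1c(-c2ccccc2)[nH]c2ccccc12)S(=O)(=O)c1ccccc1`: 400 nM
Compound 2 `CC(=O)/C(=C\c1c(-c2ccccc2)[nH]c2ccccc12)S(=O)(=O)c1ccc(Cl)cc1`: > 100000 nM
Compound 3 `CCOC(=O)/C(=C/c1c(-c2ccccc2)[nH]c2ccccc12)C(=O)c1ccc(Cl)cc1`: 9000 nM

In a functional assay on MT4 cells (Homo sapiens) for antiproliferative activity, read by MTT assay, with a stated time of 96 h (a higher number here means that more compound is needed for the effect, a lower number that less compound is needed), compound 1 gives 400 nM. For compound 2 the assay reports only a limit and not a number, namely (the limit of > 100000 nM in this assay, at which 1 of the 3 values shown sits). Compound 3 gives 9000 nM in this assay, the highest number among the two measured values. The difference between the core of compound 3 and that of compound 2 is not broken down here.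

The change from compound 2 to compound 1, hydrogen in place of chloro on an aromatic carbon, gave an at least 250-fold lower number from compound 2 to compound 1 (2.39 log units; beyond the scatter). Compound 4 `CCOC(=O)/C(=C/c1c(-c2ccccc2)[nH]c2ccccc12)C(=O)c1ccccc1` carries the same change relative to compound 3 (hydrogen in place of chloro on an aromatic carbon). Resting on that step, compound 4 is expected to give a lower number than compound 3, with a 6.0-fold lower number from compound 3 to compound 4 (0.78 log units; beyond the scatter), and its estimated value in this assay is 1500 nM (range 150 nM to 9000 nM).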

Compound 4, half-maximal effective concentration: 7000 nM
Beside the measured number, compound 4's estimate is 4.7-fold (0.67 log units) below it, and the stated range covers the measured number.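

In this assay, hydrogen in place of chloro on the core of compound 3 gave a 1.3-fold lower number from compound 3 to compound 4 (0.11 log units; within the scatter), so on this core the change has no readable effect. The same change therefore does not carry over from one core to the other with a similar size: the same change on two cores in this assay, an at least 250-fold lower number (2.39 log units; beyond the scatter) from compound 2 to compound 1 and a 1.3-fold lower number (0.11 log units; within the scatter) from compound 3 to compound 4, at least 190-fold (2.28 log units) apart, beyond the scatter of two such steps. Compound 2 has only a limit and not a number, > 100000 nM, and a single pair on each core does not show which difference between the cores sets this gap.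

The compounds shown leave open what fluoro, methoxy or an amine in place of the chloro group would give on either core. They also leave open what a carboxylic acid in place of the ethyl ester would give.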